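The compounds below may be only part of what the source reports. "The series", "measured", "known", "first", "only" and "open" are said of these compounds alone.

Of the compounds shown here, two sharing one core have been measured in an assay on isolated protein for inhibition of thyroid hormone receptor alpha (Homo sapiens), read by fluorescence polarization; a higher number here means a weaker inhibitor, a lower number a stronger inhibitor. Compound 1 `CN(CC(=O)N1CCN(c2ccccc2)CC1)C(=O)c1ccc(S(C)(=O)=O)c([N+](=O)[O-])c1` carries a plain phenyl group at one end of the molecule. In this assay compound 1 gives > 60000 nM, which is a limit of the assay rather than a number. Compound 2 `CN(Cc1cccc(F)c1)C(=O)CN(C)C(=O)c1ccc(S(C)(=O)=O)c([N+](=O)[O-])c1` is built on the same core but changes the other end of the molecule. In this assay compound 2 gives > 60000 nM, again a limit. Compound 1 therefore stands at the edge of what the assay can report, as shown by the limit of > 60000 nM in this assay, at which 2 of the 2 values shown sit. The two measured compounds differ in more than one place. For the measured compounds named here, no single step between them can be read.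

Compound 3 `CN(CC(=O)N1CCN(c2ccc(C(F)(F)F)cc2)CC1)C(=O)c1ccc(S(C)(=O)=O)c([N+](=O)[O-])c1` has not yet been measured. It differs from compound 1 in one spot: trifluoromethyl in place of hydrogen on an aromatic carbon. Going by the values given here, with both measured compounds sitting at the same limit, there is no measured step to lean on. The step from compound 1 to compound 3 is expected to be a number no higher from compound 1 to compound 3 (the limit leaves the size open), no change beyond the scatter, with the result most likely again a limit. Compound 3 is estimated at 60000 nM, within a range from 20000 nM to 300000 nM.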

Compound 3, half-maximal inhibitory concentration: > 60000 nM
Compound 3 was reported as a limit; the forecaster's own chance of this, stated with the estimate: 80%; the middle value lies on the limit itself.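

Compound 1 and compound 3 are each reported only as a limit of the assay, not as a number, so no step can be read between them. The compounds shown leave open whether trifluoromethyl in place of hydrogen changes the strength of inhibition at all, and what on the shared core would give a readable number: the limit of > 60000 nM in this assay, at which 3 of the 3 values shown sit.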